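A few compounds are considered here, and "the series" means these few. Any claim that something is new, unique, unknown or untested is made for them only; others in the source may bear on it.

Measured in an ADME assay on the whole organism with Oryza sativa as the target, tested at 10 uM; on this read-out higher numbers stand for a weaker effect at the one concentration tested and lower numbers for a stronger effect:
- compound 1 `CCc1ccc(NC(=O)N[C@H](C)c2ccccc2)cc1` gives 44%
- compound 2 `CCCCc1ccc(NC(=O)N[C@H](C)c2ccccc2)cc1` gives 28%
- compound 3 `CCCCCCc1ccc(NC(=O)N[C@H](C)c2ccccc2)cc1` gives 101%

Compound 3 stands highest of the three, separated from compound 1 by a number 57 percentage points higher from compound 1 to compound 3 (beyond the scatter) and from compound 2 by a number 73 percentage points higher from compound 2 to compound 3 (beyond the scatter), both beyond the scatter. Compound 4 `C[C@@H](NC(=O)Nc1ccc(F)cc1)c1ccccc1` differs from compound 3 by fluoro in place of hexyl on an aromatic carbon. Within the data shown here, no measured step removes the whole chain, so the bearing steps are indirect: shortening the chain from compound 3 gave the two large drops above, while the small step of a number 16 percentage points lower from compound 1 to compound 2 (beyond the scatter) went the other way. Removing the chain altogether is therefore expected to give a large step downward in this assay, about a number 61 percentage points lower from compound 3 to compound 4 (beyond the scatter). Compound 4 is expected at 40%, within 12% to 75%.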

Compound 4, a percentage reported as activity, at one concentration (the size of the read-out at that concentration, not a potency): 92%
Compound 4: middle estimate off by 52 percentage points, on the low side; measured number above the stated range.
By their numbers in this assay, from the lowest: compound 2; then compound 1; then compounds 4 and 3 (each within the scatter of the next).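

In this assay fluoro on the aromatic carbon, para to a large group, reads with hexyl (a number 9 percentage points lower from compound 3 to compound 4 (within the scatter)) and apart from both shorter chains (a number 64 percentage points higher from compound 2 to compound 4 (beyond the scatter); a number 48 percentage points higher from compound 1 to compound 4 (beyond the scatter)). Among the four groups, the low numbers therefore belong to ethyl and butyl alone, and the smallest group and the longest chain read alike. Nothing measured here bears on the cause of this pattern.

Open, from the compounds shown here alone, is whether propyl or pentyl keeps the low number. Also open, going by these compounds, is whether methoxy or a carboxylic acid at this place reads with butyl or with fluoro.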